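Permeability Outlook for Compound 3 After a Chain Swap

The source may hold more compounds than are shown below. What is called first, only, known or untested is meant among the compounds shown, and "the series" means these compounds.

Of the compounds shown here, two have been measured in an ADME assay for permeability, using PAMPA, with a stated time of 4 h, at pH 5.5; a higher number here means that the compound crosses the layer faster, a lower number that the compound crosses the layer more slowly. Compound 1 `NC/C=C\CN(C[C@H]1Cc2ncccc2CN1)[C@H]1CCCc2cccnc21` gives 28 nm/s, while compound 2 `NC(=O)NC/C=C/CN(C[C@H]1Cc2ncccc2CN1)[C@H]1CCCc2cccnc21` gives 6 nm/s, the lowest of the two numbers. Among the compounds with values here, the one step between them, a 4.7-fold lower number from compound 1 to compound 2 (0.67 log units; beyond the scatter), placed a group of 7 heavy atoms carrying an oxygen where a group of 4 heavy atoms had stood, on a saturated chain carbon bound to an amine nitrogen.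

Compound 3 `c1cnc2c(c1)CN[C@@H](CN(CCCC1CCNCC1)[C@H]1CCCc3cccnc31)C2` differs from compound 2 at that same place: a group of 8 heavy atoms (7 carbon, 1 nitrogen; one six-membered non-aromatic ring with 1 hetero atom) in place of a group of 7 heavy atoms (4 carbon, 2 nitrogen, 1 oxygen; no ring), on a saturated chain carbon bound to an amine nitrogen. The group of 7 heavy atoms, with its oxygen and its two double bonds, leaves, and 2-(piperidin-4-yl)ethyl, with its six-membered non-aromatic ring, enters.

Within the data shown here, only the step of a 4.7-fold lower number from compound 1 to compound 2 (0.67 log units; beyond the scatter) bears on this change. That step came with the arrival of the oxygen-bearing group, and compound 3, like compound 1, no longer carries it. A rise of roughly comparable size is therefore expected, a 3.3-fold higher number from compound 2 to compound 3 (0.52 log units; beyond the scatter) in this assay. Compound 3 is expected to give 20 nm/s in this assay, with a likely range from 6 nm/s to 70 nm/s.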

Compound 3, apparent permeability: 14 nm/s
The estimate for compound 3 lay 1.4-fold (0.15 log units) above the measured number; the range from low to high includes it.
By their numbers in this assay, from the lowest: compound 2; then compounds 3 and 1 (each within the scatter of the next).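

In this assay, a 2.3-fold higher number from compound 2 to compound 3 (0.37 log units; beyond the scatter) shows that the low number of compound 2 is not shared by every group on the saturated chain carbon bound to an amine nitrogen. The comparison with compound 1, a 2.0-fold lower number from compound 1 to compound 3 (0.30 log units; within the scatter) in size, adds that a group with a six-membered non-aromatic ring can stand at this place without a difference from 3-aminoprop-1-en-1-yl that can be told from the scatter. Compound 2, the only one of the three whose group holds an oxygen, thus lies beyond the scatter from both others, although three compounds are too few to tie that gap to the oxygen or to any other single feature of the group.

No measured evidence accounts for these differences. As far as these compounds go, it remains open how this read-out would respond at the same place to a carboxylic acid, a plain hexyl chain, or a piperidine ring whose nitrogen carries a methyl group, and whether a urea on a saturated chain would give a number like that of compound 2.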